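Side-chain exchange from compound 2 to compound 3

The source may report more compounds than this note shows. Statements on the series, on what has been measured and on what is new or still open speak of the compounds shown alone.

- compound 1 `C=C1C(=O)O[C@H]2CC3=C[C@H](C/C(C)=C/[C@@H](OC(=O)/C=C/c4ccc(C(F)(F)F)cc4)[C@H]12)OC3=O`: 5900 nM
- compound 2 `C=C1C(=O)O[C@H]2CC3=C[C@H](C/C(C)=C/[C@@H](OC(=O)CCCCBr)[C@H]12)OC3=O`: > 10000 nM (a limit of the assay, not a number)

Among the measured compounds shown here, in a functional assay on A549 cells (Homo sapiens) for cytotoxicity, read by MTT assay, with a stated time of 48 h (on this read-out lower numbers stand for stronger inhibition and higher numbers for weaker inhibition), compound 1 gives 5900 nM, the only true number so far. On these data alone, compound 2 stands at a limit of this assay, > 10000 nM, so its exact position is unknown.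

Compound 3 `C=C1C(=O)O[C@H]2CC3=C[C@H](C/C(C)=C/[C@@H](OC(=O)C45CCC(C)(C(=O)O4)C5(C)C)[C@H]12)OC3=O` keeps the shared core of compound 2. The change is a group of 11 heavy atoms (9 carbon, 2 oxygen; one five-membered non-aromatic ring of carbon only, one five-membered non-aromatic ring with 1 hetero atom) in place of a group of 5 heavy atoms (4 carbon, 1 bromine; no ring), on a carbonyl carbon: a group of 11 heavy atoms with two five-membered non-aromatic rings takes the place of the 4-bromobutyl, on a carbonyl carbon. For the measured compounds named here, no measured pair isolates a change of this kind, so the expectation rests on little. Going by the values given here, the number for compound 1, 5900 nM, is the only guide to where a compound on this core is expected to fall. The estimated a number no higher from compound 2 to compound 3 (the limit leaves the size open) is expected to stay within the usual scatter, with no clear direction. A report of a limit alone would also be no surprise. For compound 3 the expected value is 10000 nM, with an estimated range from 4000 nM to 25000 nM.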

Compound 3, half-maximal inhibitory concentration: 3400 nM
Compound 3: the middle estimate sits 2.9-fold (0.47 log units) above what was measured; measured number outside the range, below it.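

In this assay, replacing the 4-bromobutyl on the carbonyl carbon with the group carrying two five-membered non-aromatic rings gives an at least 2.9-fold lower number from compound 2 to compound 3 (0.46 log units; beyond the scatter). Among the compounds shown here, this is the first readable step and shows that the number at this position responds to the side chain, even on an unchanged shared core. The size of the step remains a minimum, because compound 2 stands at a limit of the assay and not at a number: the limit of > 10000 nM in this assay, at which 1 of the 3 values shown sits.

The entering group differs from the 4-bromobutyl in several ways at once, so the compounds shown do not separate the contribution of its carbon-only ring from that of its ring with one hetero atom, or show which part of the group goes with the lower number. On these data alone, how an amine, a carboxylic acid or a chain longer than the 4-bromobutyl would read on the same carbonyl carbon also stays open, as does whether any such group would give a true number in this assay.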